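The source may report more compounds than this note shows. Statements on the series, on what has been measured and on what is new or still open speak of the compounds shown alone.

In a physicochemical assay for solubility (on this read-out higher numbers stand for higher solubility and lower numbers for lower solubility), compound 1 `NS(=O)(=O)c1ccc(NC(=O)c2cc(Cl)ccc2O)cc1` gives > 48 ug/mL as a limit of the assay. Compound 2 `O=C(Nc1ccc(C(F)(F)F)cc1)c1cc(Cl)ccc1O` gives < 1 ug/mL as a limit too, and so stands at the limit of < 1 ug/mL in this assay, at which 2 of the 3 values shown sit, without a number of its own. Compound 3 `Cc1ccc(NC(=O)c2cc(Cl)ccc2O)cc1` gives < 1 ug/mL which is again a limit. Compound 4 `O=C(Nc1ccc(C(F)(F)F)cc1)c1cc(Br)ccc1O` carries bromo in place of chloro on an aromatic carbon, para to a hydroxy group (bromo in place of chloro on an aromatic carbon). Replacing sulfamoyl gave the large steps of an at least 48-fold lower number from compound 1 to compound 2 (1.68 log units; beyond the scatter) and an at least 48-fold lower number from compound 1 to compound 3 (1.68 log units; beyond the scatter) but neither touches chloro. Among the compounds with values here, exchanging trifluoromethyl for methyl gave a step that the two limits leave unreadable from compound 2 to compound 3 and no measured step alters chloro. Nothing beyond the scatter is therefore expected in this assay in either direction. The expected step is a step that the limit leaves unreadable from compound 2 to compound 4 on this estimate. Compound 4 is estimated at 0.5 ug/mL (expected range 0.2 ug/mL to 1 ug/mL).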

Compound 4, solubility: < 1 ug/mL
Compound 4 gave a limit, no number; the forecaster's own chance of this, stated with the estimate: 90%; the middle value does not contradict the limit.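

Compound 2 and compound 4 both give only limits in this assay, so the step between them cannot be read. The compounds shown leave open whether bromo in place of chloro on an aromatic carbon moves the read-out of this assay at all.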